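This account rests on a few compounds, and the source may have more. Where it says the series, first, only, none or still open, it means among the compounds named here.

Compounds measured so far in an ADME assay on L02 cells (Homo sapiens) for inhibition, read by MTT assay, with a stated time of 48 h, tested at 100 uM; a lower number here means less inhibition, a higher number more inhibition at the concentration tested (going by the name of the read-out):

compound 1 `Cc1ccccc1-c1nc(=O)ss1` — 18.6%
compound 2 `O=c1nc(-c2ccccc2Cl)ss1` — 40.1%

Compound 2 stands highest of the two numbers in this assay; its nearest neighbour is compound 1, separated by a step of a number 21.5 percentage points higher from compound 1 to compound 2 (beyond the scatter), which lies beyond the scatter. For the measured compounds named here, the only measured step, chloro in place of methyl on an aromatic carbon, is thus modest and upward.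

Compound 3 `O=c1nc(-c2ccccc2[N+](=O)[O-])ss1` is the next member and has not yet been measured. It differs from compound 2 in one place: nitro in place of chloro on an aromatic carbon. Going by the values given here, only the step of a number 21.5 percentage points higher from compound 1 to compound 2 (beyond the scatter) bears on this change, and only loosely: it shows that exchanging the group on that aromatic carbon can shift the read-out by a modest amount, but neither measured compound carries a nitro group, so the series gives no direction for this particular exchange. The step expected here is a number 4.9 percentage points higher from compound 2 to compound 3 (within the scatter), small relative to the uncertainty around it. For compound 3 the value in this assay is estimated at 45%, with a likely range from 20% to 70%.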

Compound 3, a percentage reported as inhibition, at one concentration (the size of the read-out at that concentration, not a potency): 33%
Compound 3: middle estimate off by 12 percentage points, on the high side; measured number inside the range.
By their numbers in this assay, from the lowest: compound 1; then compounds 3 and 2 (each within the scatter of the next).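

In this assay, the exchange of chloro for nitro gives a number 7.1 percentage points lower from compound 2 to compound 3 (within the scatter), so at this aromatic carbon, ortho to a group of 6 heavy atoms, going from 1 heavy atom to 3 heavy atoms with 2 hydrogen-bond acceptors leaves no separable difference in the read-out. The other new step, a number 14.4 percentage points higher from compound 1 to compound 3 (beyond the scatter), stands with a number 21.5 percentage points higher from compound 1 to compound 2 (beyond the scatter), which makes compound 1, the methyl member, the lowest of the three, while compound 2 and compound 3 cannot be told apart; this holds for these three compounds only, and none of them goes against it. Nothing on hand accounts for these numbers.

Still open, going by these compounds, is whether other groups on this carbon, such as an amine, a carboxylic acid, a methoxy or a longer alkyl chain, would read with the methyl of compound 1 or with the chloro and nitro of compound 2 and compound 3. Also open, on these data alone, is whether chloro and nitro would stay inseparable on another carbon of the ring, or at other concentrations in this assay, since each number here comes from a single concentration.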